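The compounds below may be only part of what the source reports. "The series", "measured", "known", "first", "only" and "open" are said of these compounds alone.

Three compounds sharing one core were measured in a functional assay on HepG2 cells (Homo sapiens) for cytotoxicity, read by MTT assay, with a stated time of 3 days; a lower number here means a stronger inhibitor, a higher number a weaker inhibitor. Compound 1, with structure `Cc1ccc2nc(C)n(NC(=O)/C(C#N)=C/c3ccccc3)c(=O)c2c1`, gave 14000 nM in this assay. Compound 2, with structure `Cc1ccc2nc(C)n(NC(=O)c3cc4ccccc4oc3=N)c(=O)c2c1`, gave 23000 nM in this assay. Compound 3, with structure `Cc1ccc2nc(C)n(-n3c(N)c(C#N)c(-c4ccccc4)c(C#N)c3=O)c(=O)c2c1`, gave 10000 nM in this assay. Among these three numbers compound 3 has the lowest; its number lies within the usual scatter of that of compound 1, so no order between those two can be claimed, while the number of compound 2 is higher by more than the scatter.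

Compound 4, with structure `CCOC(=O)c1c(-c2ccccc2)c(C#N)c(=O)n(-n2c(C)nc3ccc(C)cc3c2=O)c1N`, has not yet been measured in this assay. Compared with compound 3 the change is this: ethoxycarbonyl in place of cyano on an aromatic carbon. Within the data shown here, there is no measured pair here in which one group alone is exchanged, so no earlier step in this assay shows what such a swap does. The three measured numbers all sit in a narrow band, and the change from compound 3 to compound 4 is a single exchange of one small group for another on the same ring carbon. The expected step from compound 3 to compound 4 in this assay is therefore a 1.2-fold higher number from compound 3 to compound 4 (0.08 log units; within the scatter), nothing beyond the scatter in either direction. Compound 4 is estimated at 12000 nM in this assay, with a range from 5000 nM to 30000 nM.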

Compound 4, half-maximal inhibitory concentration: 52000 nM
Compound 4: the middle estimate sits 4.3-fold (0.64 log units) below what was measured; the measured number lies above the stated range.
By their numbers in this assay, from the lowest: compounds 3, 1 and 2 (each within the scatter of the next, the first and the last beyond it); then compound 4.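

In this assay, among these compounds, the carbon that is ortho to a phenyl group and ortho to an amino group gives the first single exchange that can be read: ethoxycarbonyl in place of cyano produces a 5.2-fold higher number from compound 3 to compound 4 (0.72 log units; beyond the scatter) and moves the compound to a weaker number. The shared core and the other substituents therefore do not make this position indifferent to what it carries, at least for this one pair. The exchange replaces a cyano group of 2 heavy atoms and 1 hydrogen-bond acceptor with an ethoxycarbonyl group of 5 heavy atoms and 2 hydrogen-bond acceptors, but no measured evidence says which of these differences, if any, accounts for the step. On these data alone, whether the ester function itself or the length of its ethyl chain matters stays open, and a methoxycarbonyl group, a carboxylic acid or a primary carboxamide on the same carbon would help to separate the two. Also open, as far as these compounds go, is whether exchanging the second cyano group of compound 3 would give a step of similar size.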